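Nitrile in place of methoxy on the shared core

The source may report more compounds than this note shows. Statements on the series, on what has been measured and on what is new or still open speak of the compounds shown alone.

Of the three compounds measured in an in vitro assay on Sf21 cells for inhibition of high affinity 3',5'-cyclic-AMP phosphodiesterase 7A (Homo sapiens) (a higher number here means a weaker inhibitor, a lower number a stronger inhibitor), only compound 2 `CNc1nc(NC2(C#N)CCCCC2)nc(OC)n1` returns a number: compound 2 gives 521 nM. Compound 1 `CNc1nc(NC2(C#N)CCCCC2)nc(-n2cncn2)n1` reaches only a limit of the assay, > 5000 nM. Compound 3 `CNc1nc(NC2(C#N)CCCCC2)nc(-n2cnc3ccccc32)n1` likewise reaches only a limit, > 1000 nM. Within the data shown here, the single measured step, an at least 9.5-fold lower number from compound 1 to compound 2 (0.98 log units; beyond the scatter), is an at-least figure, since compound 1 sits at the limit of > 5000 nM in this assay, at which 1 of the 3 values shown sits. Compound 4 `CNc1nc(C#N)nc(NC2(C#N)CCCCC2)n1` differs from compound 2 by cyano in place of methoxy on an aromatic carbon. Among the measured compounds shown here, no measured step exchanges methoxy for cyano, so the measured step bears on it only indirectly: it shows that a small group at this carbon is tolerated where a ring was not, and cyano is again a small group of two heavy atoms. The step in this assay from compound 2 to compound 4 is therefore expected to be small, with no direction settled beyond the scatter. Compound 4 is estimated at 800 nM, with a range from 250 nM to 2500 nM, which would mean a 1.5-fold higher number from compound 2 to compound 4 (0.19 log units; within the scatter).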

Compound 4, half-maximal inhibitory concentration: > 1000 nM
Compound 4: no number, only a limit; the forecaster's own chance of this, stated with the estimate: 15%; middle value at least 1.2-fold (0.09 log units) from the limit.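

Compound 4 returns only a limit in this assay, > 1000 nM. A small group with no ring at this aromatic carbon therefore does not by itself give a readable number: methoxy does so in compound 2, while cyano, also of 2 heavy atoms, does not. The step is an at least 1.9-fold higher number from compound 2 to compound 4 (0.28 log units; that floor lies within the scatter), which gives no sign of a gain from cyano over methoxy but does not establish a loss beyond the scatter.

Going by these compounds, the step between compound 1 and compound 4 cannot be read, as both carry only limits, and how far the true value of compound 4 lies from its limit stays open. Also open, on these data alone, is how an ethoxy group or an amine at this carbon would compare with methoxy.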